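Nitro for chloro on the imine aryl ring of a hydrazide

The source may hold more compounds than are shown below. What is called first, only, known or untested is meant among the compounds shown, and "the series" means these compounds.

The series shares a core and varies the aryl ring on the carbon with a double bond to nitrogen. In a physicochemical assay for lipophilicity, measured as octanol-water partition (on this read-out higher numbers stand for higher lipophilicity and lower numbers for lower lipophilicity), compound 1 `O=C(COc1cccc2ccccc12)N/N=C/c1ccc(Cl)cc1` gives 4.54. Compound 2 `O=C(COc1cccc2ccccc12)N/N=C/c1ccc([N+](=O)[O-])cc1` differs from compound 1 in that (nitro in place of chloro on an aromatic carbon); in this assay compound 2 gives 3.97, so that the step is a number 0.57 log units lower from compound 1 to compound 2 (beyond the scatter). Compound 3 `O=C(COc1cccc2ccccc12)N/N=C/c1ccccc1Cl` differs from compound 1 only in how the same atoms are joined: 2-chlorophenyl in place of 4-chlorophenyl on a carbon with a double bond to nitrogen. In this assay compound 3 gives 4.54, and the step is no change at the digits printed from compound 1 to compound 3 (within the scatter), so compound 3 and compound 1 stand level, and both stand furthest from compound 2.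

Compound 4 `O=C(COc1cccc2ccccc12)N/N=C/c1ccccc1[N+](=O)[O-]` is not yet measured. Relative to compound 3 the change is nitro in place of chloro on an aromatic carbon. This is the same kind of change as that from compound 1 to compound 2, but not the same: in compound 2 the entering group is para to a large group, whereas in compound 4 it is ortho to a large group. Going by the values given here, the step from compound 3 to compound 4 is expected to be a number 0.57 log units lower from compound 3 to compound 4 (beyond the scatter), a judgement resting on the single earlier instance, a number 0.57 log units lower from compound 1 to compound 2 (beyond the scatter), and on compound 1 standing level with compound 3 at 4.54. For compound 4 the estimate in this assay is therefore 3.97, expected to fall between 3.6 and 4.35.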

Compound 4, partition coefficient: 3.97
Compound 4: middle estimate and measured number agree at the digits printed; measured number inside the range.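

In this assay, the change of nitro in place of chloro gives a number 0.57 log units lower from compound 3 to compound 4 (beyond the scatter), and the earlier instance of the same change gives a number 0.57 log units lower from compound 1 to compound 2 (beyond the scatter); the two steps print the same size, although in compound 4 the entering group stands ortho to a large group and in compound 2 it does not. This shows that, in these two pairs, moving the change from the 4-chlorophenyl compound to the 2-chlorophenyl compound left its size unaltered at the digits printed, so the step read from one pair would have served for the other. Going by these compounds alone, it rests on only two pairs that share everything outside the aryl ring, so it does not show that the step would hold on a different core or amount to a rule for the series, and no measurement given here bears on what lies behind the agreement between the two steps.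

The compounds shown carry only chloro or nitro on the aryl ring, so it remains open whether an amine, a carboxylic acid or a methoxy group would follow any similar pattern across the two placements. Also open, on these data alone, is whether the nitro-for-chloro step would keep its size if the chain joining the shared core to the hydrazide were replaced by a longer chain.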